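The source may report more compounds than this note shows. Statements on the series, on what has been measured and on what is new or still open speak of the compounds shown alone.

Of the compounds shown here, two have been measured in a functional assay on the whole organism for inhibition, with Rattus norvegicus as the target, at a dose of 3 mg/kg by the oral route; on this read-out higher numbers stand for a stronger effect at the one dose given and lower numbers for a weaker effect. Compound 1 `CC(C)c1ccnc(C(=O)Nc2nn[nH]n2)c1` gives 34% in this assay, and compound 2 `O=C(Nc1nn[nH]n1)c1cccc(Cl)n1` gives 18% in this assay. Compound 1 therefore stands as the higher of the two numbers, and its gap to compound 2 lies beyond the scatter of repeated measurements. For the measured compounds named here, no step between two measured compounds that differ in a single place has been recorded, so no measured change of that kind can be set beside the one considered here.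

Compound 3 `CCc1ccnc(C(=O)Nc2nn[nH]n2)c1` has not yet been measured in this assay. It differs from compound 1 by hydrogen in place of methyl on a saturated chain carbon bound to an aromatic carbon and a saturated chain carbon. The shared core of compound 1 and compound 3 is untouched by this change.

Going by the values given here, with only two measured numbers and no recorded single-place step, the step in this assay is expected to be small, most likely slightly downward but not beyond the scatter, and is estimated as a number 6 percentage points lower from compound 1 to compound 3 (within the scatter). Compound 3 is accordingly expected to give about 28% in this assay, within an estimated range from 12% to 44%.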

Compound 3, a percentage reported as inhibition, in the whole organism at one dose (the size of the read-out at that dose, not a potency): 29%
Compound 3: middle estimate off by 1 percentage points, on the low side, and the stated range covers the measured number.
By their numbers in this assay, from the lowest: compound 2; then compounds 3 and 1 (each within the scatter of the next).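

In this assay, for the compounds shown here, the change from isopropyl to ethyl gives the first single-place step, a number 5 percentage points lower from compound 1 to compound 3 (within the scatter). Taking away one methyl, a single carbon, on a saturated chain carbon bound to an aromatic carbon and a saturated chain carbon therefore leaves the read-out at this one dose inside the usual scatter, so on this evidence the two chains cannot be told apart, something the earlier pair of compounds, which offered no single-place comparison, could not show. No supporting measurement is available that bears on what lies behind this result.

What the compounds shown leave open is whether a longer chain, a tert-butyl group, an amine or a carboxylic acid at this place would move the number beyond the scatter, in either direction, or would likewise leave it unchanged within the scatter. From the compounds shown here alone, since this assay reports the size of the effect at a single oral dose and not a potency, it also remains open whether compound 1 and compound 3 would separate at other doses.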